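Swapping tert-butyl for methoxycarbonyl on compound 1

The compounds below may be only part of what the source reports. "The series", "measured", "known", "first", "only" and "open" are said of these compounds alone.

In a physicochemical assay for solubility, at pH 7.4 (on this read-out higher numbers stand for higher solubility and lower numbers for lower solubility), compound 1 (`Cc1cc(NC(=O)Nc2ccc(C(C)(C)C)cc2)c2ccccc2n1`) gives 6200 nM, within the scatter of compound 2 (`Cc1cc(NC(=O)Nc2ccccc2OC(F)(F)F)c2ccccc2n1`) at 4600 nM. Both stand well under compound 3 (`Cc1cc(NC(=O)Nc2ccccc2N)c2ccccc2n1`) at 51800 nM. Compound 4 (`COC(=O)c1ccc(NC(=O)Nc2cc(C)nc3ccccc23)cc1`) differs from compound 1 by one change, methoxycarbonyl in place of tert-butyl on an aromatic carbon, para to a large group (methoxycarbonyl in place of tert-butyl on an aromatic carbon). Within the data shown here, the only measured step, an 11-fold higher number from compound 2 to compound 3 (1.05 log units; beyond the scatter), is large, but it exchanges different groups and is a weak guide here. Among the measured compounds shown here, no measured step involves tert-butyl or methoxycarbonyl. The estimated step is a 1.5-fold higher number from compound 1 to compound 4 (0.16 log units; within the scatter), a small rise expected to stay within the scatter. For compound 4 the estimated value is 9000 nM, with an expected range of 2500 nM to 30000 nM.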

Compound 4, solubility: 1200 nM
The estimate for compound 4 lay 7.5-fold (0.88 log units) above the measured number, and the stated range ends above it.
By their numbers in this assay, from the lowest: compound 4; then compounds 2 and 1 (each within the scatter of the next); then compound 3.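

In this assay the position on an aromatic carbon, para to a large group, responds to what it carries: methoxycarbonyl in place of tert-butyl brings a 5.2-fold lower number from compound 1 to compound 4 (0.71 log units; beyond the scatter) even though both groups hold 4 heavy atoms. Matching heavy-atom count at this place therefore does not keep the number level. Nothing at hand bears on why the number falls. From the compounds shown here alone, whether a carboxylic acid or an amine at this place would lower the number further or raise it stays open, as does whether the step would recur on another of the shared core's substitution patterns.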